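A few compounds are considered here, and "the series" means these few. Any claim that something is new, unique, unknown or untested is made for them only; others in the source may bear on it.

Compound 1 `Cc1cccc(C)c1Oc1nc(Nc2ccc(C#N)cc2)nc2ccccc12` is one of three compounds with numbers in an ADME assay on MT4 cells (Homo sapiens) for cytotoxicity, read by MTT assay, with a stated time of 4 days; a lower number here means that less compound is tolerated, a higher number that more compound is tolerated. There compound 1 gives 35000 nM, the lowest of the three. Compound 2 `COc1cc(C#N)cc(Cl)c1Oc1nc(Nc2ccc(C#N)cc2)nc2ccccc12` gives 220000 nM, and compound 3 `Cc1cc(C#N)cc(C)c1Oc1nc(Nc2ccc(C#N)cc2)nc2ccc(Cl)cc12` gives 117000 nM; both stand beyond the scatter above compound 1. Compound 4 `Cc1ccc(Oc2nc(Nc3ccc(C#N)cc3)nc3ccccc23)cc1` has not yet been measured. It differs from compound 1 in one place: 4-methylphenyl in place of 2,6-dimethylphenyl on an oxygen on an aromatic ring. Among the compounds with values here, no measured pair of compounds shows this same change, so its size cannot be read from the data. A step from compound 1 to compound 4 of a 1.1-fold higher number from compound 1 to compound 4 (0.06 log units; within the scatter) is expected, a small shift within the scatter rather than a clear move in either direction. Compound 4 is therefore estimated at 40000 nM, with a range from 15000 nM to 110000 nM.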

Compound 4, half-maximal cytotoxic concentration: 87000 nM
Beside the measured number, compound 4's estimate is 2.2-fold (0.34 log units) below it; low and high end bracket the measured number.
By their numbers in this assay, from the lowest: compound 1; then compounds 4, 3 and 2 (each within the scatter of the next, the first and the last beyond it).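

With 4-methylphenyl in place of 2,6-dimethylphenyl on an oxygen on an aromatic ring, this assay shows a 2.5-fold higher number from compound 1 to compound 4 (0.40 log units; beyond the scatter). Within the data shown here, this is the first change in the set confined to one place, and it shows that the group on this oxygen can by itself move the tolerated concentration beyond the scatter, though only modestly. From the compounds shown here alone, how 2-methylphenyl, plain phenyl or a phenyl carrying an amine would stand here remains open, so the loss of one methyl and the move of the other cannot be told apart. Nothing given here accounts for the shift.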